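The source may report more compounds than this note shows. Statements on the series, on what has been measured and on what is new or still open speak of the compounds shown alone.

Measured so far:
compound 1 `COc1ccc(S(=O)(=O)c2cnc3cc(F)ccc3c2N2CCC(C)CC2)cc1OC` — 83%
compound 2 `O=S(=O)(c1ccccc1)c1cnc2ccccc2c1N1CCCCCC1` — 79.9%

In an assay on isolated protein for displacement of a labelled ligand from metabotropic glutamate receptor 5 (Homo sapiens), with a stated time of 60 min, tested at 1 uM (on this read-out higher numbers stand for more inhibition at the one concentration tested (going by the name of the read-out) and lower numbers for less inhibition), compound 1 gives 83%, the highest of the two numbers. Compound 2 gives 79.9%, which lies within the scatter of compound 1, so no order between the two can be claimed. Compound 3 `CC1CCN(c2c(S(=O)(=O)c3cccc(C#N)c3)cnc3cc(F)ccc23)CC1` differs from compound 1 by 3-cyanophenyl in place of 3,4-dimethoxyphenyl on a sulfonyl sulfur. Going by the values given here, no measured pair shows a step of this kind, so the expected step of a number 9 percentage points lower from compound 1 to compound 3 (within the scatter) is small and not beyond the scatter, with a slight lean downward. Compound 3 is therefore estimated at 74% in this assay, with a range from 50% to 92%.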

Compound 3, a percentage reported as inhibition, at one concentration (the size of the read-out at that concentration, not a potency): 92%
The estimate for compound 3 lay 18 percentage points below the measured number; the range from low to high includes it.
By their numbers in this assay, from the lowest: compounds 2, 1 and 3 (each within the scatter of the next, the first and the last beyond it).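

In this assay, going by these compounds alone, the only pair differing in one place gives a number 9 percentage points higher from compound 1 to compound 3 (within the scatter), so 3-cyanophenyl and 3,4-dimethoxyphenyl on the sulfonyl sulfur cannot be told apart at this single concentration. A nitrile-bearing ring therefore keeps the read-out in the same range as a ring carrying two methoxy groups. Nothing at hand bears on the reason for this outcome. Going by these compounds, it remains open how a carboxylic acid or an amine on this phenyl ring would read. Potency also remains open, since one concentration gives no measure of it.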